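Cytotoxicity notes: from compound 1 to compound 4

The compounds below may be only part of what the source reports. "The series", "measured", "known", "first", "only" and "open" are said of these compounds alone.

Measured in an ADME assay on MT4 cells (Homo sapiens) for cytotoxicity, read by MTT assay, with a stated time of 5 days; on this read-out higher numbers stand for lower toxicity in this test and lower numbers for higher toxicity in this test:
- compound 1 `Cc1ccc(NC(=O)CSc2nc3ccccc3n2S(=O)(=O)c2cc(C)cc(C)c2)cc1` gives 2970 nM
- compound 2 `Cc1cc(C)cc(S(=O)(=O)n2c(OCC(=O)Nc3ccccc3Cl)nc3ccccc32)c1` gives 169000 nM
- compound 3 `Cc1cc(C)cc(S(=O)(=O)n2c(OCC(=O)Nc3ccc(S(C)(=O)=O)cc3Cl)nc3ccccc32)c1` gives > 228000 nM (a limit, not a number)

Compound 1 at 2970 nM holds the lowest of the two actual numbers, and the gap to compound 2 at 169000 nM lies beyond the scatter. Compound 3 reports only a limit, > 228000 nM, so it cannot be ranked by number.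

The change to compound 4 `COC(=O)c1ccc(NC(=O)CSc2nc3ccccc3n2S(=O)(=O)c2cc(C)cc(C)c2)c(Cl)c1` is 2-chloro-4-(methoxycarbonyl)phenyl in place of 4-methylphenyl on an amide-type nitrogen.

Among the measured compounds shown here, only one measured step is available, an at least 1.3-fold higher number from compound 2 to compound 3 (0.13 log units; that floor lies within the scatter), which places methylsulfonyl in place of hydrogen on an aromatic carbon. Its floor lies within the scatter, and it is a different change from the one at hand, so it bears only loosely. For the measured compounds named here, no measured step covers the loss of 4-methylphenyl.

With compound 1 at 2970 nM and compound 2 at 169000 nM, a higher number in this assay is expected, though not one as high as that of compound 2. The expected size is a 5.1-fold higher number from compound 1 to compound 4 (0.70 log units; beyond the scatter), an estimate with wide uncertainty. For compound 4 the estimated value is 15000 nM, with an expected range from 3000 nM to 80000 nM.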

Compound 4, half-maximal cytotoxic concentration: 145000 nM
Compound 4: middle estimate off by 9.7-fold (0.99 log units), on the low side; the measured number lies above the stated range.
By their numbers in this assay, from the lowest: compound 1; then compounds 4 and 2 (each within the scatter of the next). At a limit, above all of these: compound 3.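

In this assay, putting 2-chloro-4-(methoxycarbonyl)phenyl in place of 4-methylphenyl on the amide-type nitrogen gives a 49-fold higher number from compound 1 to compound 4 (1.69 log units; beyond the scatter), while the rest of compound 1 stays unchanged. Among the compounds shown here, this is the first step at this position that is printed as beyond the scatter, so the low number of compound 1 does not belong to the shared core alone: with that core kept, the number moves strongly with the group on the nitrogen. The upper end of the numbers shown is marked only by compound 3, which reports a limit and not a number: the limit of > 228000 nM in this assay, at which 1 of the 4 values shown sits.

For the compounds shown here, the single step exchanges 4-methylphenyl for a group that differs from it in more than one feature, so the chlorine and the methoxycarbonyl cannot be separated here, and how much each contributes stays open. Also open, on these data alone, is how a carboxylic acid in place of the methoxycarbonyl, or an amine in place of the chlorine, would read in this assay, and whether either would keep the number of compound 4 on the same side of compound 1.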